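Amine substituent swaps on the shared core

This account rests on a few compounds, and the source may have more. Where it says the series, first, only, none or still open, it means among the compounds named here.

Going by the values given here, in a functional assay on MCF7 cells (Homo sapiens) for cytotoxicity, read by MTT assay, with a stated time of 48 h (on this read-out higher numbers stand for weaker inhibition and lower numbers for stronger inhibition), compound 1 `Cc1ccc(S(=O)(=O)/N=C(/CCNC2=CC(=O)c3ccccc3C2=O)Nc2ccccc2[N+](=O)[O-])cc1` gives 3090 nM, the second highest of the three numbers measured so far. Compound 2 `COc1cc(N/C(CCNC2=CC(=O)c3ccccc3C2=O)=N\S(=O)(=O)c2ccc(C)cc2)cc(OC)c1OC` gives 3050 nM and compound 3 `Cc1ccc(S(=O)(=O)/N=C(/CCNC2=CC(=O)c3ccccc3C2=O)NCc2ccccc2)cc1` gives 3630 nM. The steps of a 1.0-fold lower number from compound 1 to compound 2 (0.01 log units; within the scatter) and a 1.2-fold higher number from compound 1 to compound 3 (0.07 log units; within the scatter) both replace the group on the same amine nitrogen and stay within the scatter, as does a 1.2-fold higher number from compound 2 to compound 3 (0.08 log units; within the scatter). Compound 4 `Cc1ccc(S(=O)(=O)/N=C(/CCNC2=CC(=O)c3ccccc3C2=O)NC2CCCCC2)cc1` differs from compound 1 in one place: cyclohexyl in place of 2-nitrophenyl on an amine nitrogen. The measured steps all bear on this change, since each alters that group, though none brought in a non-aromatic ring. For compound 4 the expected step is a 1.1-fold higher number from compound 1 to compound 4 (0.03 log units; within the scatter), nothing beyond the scatter. Compound 4 is therefore estimated at 3300 nM, with a range from 1500 nM to 7500 nM.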

Compound 4, half-maximal inhibitory concentration: 7580 nM
The estimate for compound 4 lay 2.3-fold (0.36 log units) below the measured number; measured number above the stated range.
By their numbers in this assay, from the lowest: compounds 2, 1 and 3 (each within the scatter of the next); then compound 4.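

In this assay the group on this amine nitrogen first matters with cyclohexyl, the only non-aromatic ring of the four: a 2.5-fold higher number from compound 1 to compound 4 (0.39 log units; beyond the scatter) and a 2.5-fold higher number from compound 2 to compound 4 (0.40 log units; beyond the scatter) and a 2.1-fold higher number from compound 3 to compound 4 (0.32 log units; beyond the scatter) all lie beyond the scatter. The 2-nitrophenyl, 3,4,5-trimethoxyphenyl and benzyl compounds stay within the scatter of each other, so what sets compound 4 apart here is the non-aromatic ring, not which aromatic group leaves. No measurement at hand explains the step. Still open, going by these compounds, is whether any non-aromatic group behaves this way: a cyclopentyl ring or an open hexyl chain on the same nitrogen would test ring size and the ring itself.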